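A few compounds are considered here, and "the series" means these few. Any claim that something is new, unique, unknown or untested is made for them only; others in the source may bear on it.

The three measured compounds share one core and differ only at the ring on the amide-type nitrogen. In a functional assay on Huh-7 cells (Homo sapiens) for inhibition, read by MTT assay, with a stated time of 48 h (a higher number here means a weaker inhibitor, a lower number a stronger inhibitor), compound 2 `COc1ccc2c(=O)c(/C=C/C(=O)Nc3ccccc3)coc2c1` gives 9050 nM. Compound 3 `COc1ccc2c(=O)c(/C=C/C(=O)Nc3ccc(Cl)cc3)coc2c1` gives 37100 nM, the highest of the two numbers shown, and its nearest neighbour is compound 2, separated by a 4.1-fold higher number from compound 2 to compound 3 (0.61 log units; beyond the scatter). For compound 1 `COc1ccc2c(=O)c(/C=C/C(=O)Nc3cccc(Cl)c3)coc2c1` the result is a limit, > 100000 nM, rather than a number (the limit of > 100000 nM in this assay, at which 1 of the 3 values shown sits). From that limit the moves read as an at least 11-fold lower number from compound 1 to compound 2 (1.04 log units; beyond the scatter) and an at least 2.6-fold lower number from compound 1 to compound 3 (0.43 log units; beyond the scatter).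

Compound 4 `CCOc1ccc(NC(=O)/C=C/c2coc3cc(OC)ccc3c2=O)cc1` has not yet been measured. It differs from compound 3 in one place: ethoxy in place of chloro on an aromatic carbon. Going by the values given here, no measured step puts ethoxy on this ring, so the bearing evidence is indirect. Among the compounds with values here, the only step that touches the same aromatic carbon is a 4.1-fold higher number from compound 2 to compound 3 (0.61 log units; beyond the scatter), a modest move, and compound 4 neither returns to the hydrogen of compound 2 nor keeps the chloro of compound 3. The chemist therefore expects no large shift in this assay, with a modest change in either direction possible, and estimates the step as a 1.9-fold lower number from compound 3 to compound 4 (0.27 log units; within the scatter). The estimate for compound 4 in this assay is 20000 nM, expected to fall between 6000 nM and 70000 nM.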

Compound 4, half-maximal inhibitory concentration: 3230 nM
Estimate against measurement, compound 4: 6.2-fold (0.79 log units) above; measured number outside the range, below it.
By their numbers in this assay, from the lowest: compound 4; then compound 2; then compound 3. At a limit, above all of these: compound 1.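

In this assay, the carbon para to a large group now proves able to move the result in both directions from hydrogen: chloro gave a 4.1-fold higher number from compound 2 to compound 3 (0.61 log units; beyond the scatter), whereas ethoxy gives a 2.8-fold lower number from compound 2 to compound 4 (0.45 log units; beyond the scatter). Going by these compounds alone, exchanging one substituent for the other, 4-chlorophenyl to 4-ethoxyphenyl, gives an 11-fold lower number from compound 3 to compound 4 (1.06 log units; beyond the scatter), so the identity of the group at this carbon matters more than the earlier compounds could show, and compound 4 is the strongest inhibitor of the four. The comparison with the 3-chlorophenyl compound, an at least 30-fold lower number from compound 1 to compound 4 (1.49 log units; beyond the scatter), gives only a bound, since the result for compound 1 is a limit and not a number: the limit of > 100000 nM in this assay, at which 1 of the 4 values shown sits.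

As far as these compounds go, what remains open is whether the lower number is particular to ethoxy or also appears with methoxy, a longer chain such as propoxy, or an amine at this carbon, and whether ethoxy would behave the same way at the ring position held by the chloro of compound 1. With only hydrogen, chloro and ethoxy at this carbon, the compounds shown give no explanation for why the two substituents move the result in opposite directions.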